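Trading one small amide substituent for another

A few compounds are considered here, and "the series" means these few. Any claim that something is new, unique, unknown or untested is made for them only; others in the source may bear on it.

Of the compounds shown here, three built on one shared core have been measured in a functional assay on the whole organism with Rattus norvegicus as the target, at a dose of 20 mg/kg by the oral route; a higher number here means more inhibition at the dose given (going by the name of the read-out), a lower number less inhibition. Compound 1 `NC(=O)/C=C1\CCc2cc(Cl)ccc21` gives 30%. Compound 2 `O=C(/C=C1\CCc2ccc(F)cc21)NCC1CC1` gives 0%, and compound 3 `CNC(=O)/C=C1\CCc2ccc(Cl)cc21` gives 0%. On these numbers compound 2 stands level with compound 3, the two together forming the bottom of the set, while compound 1 sits above both by a gap that lies beyond the usual scatter of this kind of measurement.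

Compound 4 `CC(C)NC(=O)/C=C1\CCc2ccc(F)cc21` has not yet been measured. It differs from compound 2 in a single place: isopropyl in place of cyclopropylmethyl on an amide-type nitrogen. The amide-type nitrogen and its carbonyl neighbour stay as they are; only the carbon group on that nitrogen is exchanged.

Within the data shown here, no measured pair shows the effect of exactly this exchange, so the outlook rests on the neighbours. Both compounds carrying a carbon group on the amide nitrogen, compound 2 and compound 3, show no inhibition. The step from compound 2 to compound 4 is therefore expected to be small, a number 5 percentage points higher from compound 2 to compound 4 (within the scatter), with no change beyond the scatter. Compound 4 is expected to give 5%, most likely lying between 0% and 25%.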

Compound 4, a percentage reported as inhibition, in the whole organism at one dose (the size of the read-out at that dose, not a potency): 45%
The estimate for compound 4 lay 40 percentage points below the measured number; the whole stated range lies below it.
By their numbers in this assay, from the lowest: compounds 2 and 3 (each within the scatter of the next); then compound 1; then compound 4.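

In this assay, isopropyl in place of cyclopropylmethyl on the amide-type nitrogen gives a number 45 percentage points higher from compound 2 to compound 4 (beyond the scatter). This shows that a carbon group at this position does not in itself rule out inhibition, and that the choice of group matters: a modest exchange, which removes the three-membered ring and one carbon and leaves the hydrogen-bond donor and acceptor counts unchanged, is enough to produce a large step. No measurement here explains why this exchange has so large an effect.

As far as these compounds go, it remains open whether the loss of the ring, the branching of isopropyl or the smaller size of the group matters most. An ethyl, cyclopropyl or tert-butyl group on the same nitrogen, with the rest of compound 4 unchanged, could help separate these possibilities.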